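The source may report more compounds than this note shows. Statements on the series, on what has been measured and on what is new or still open speak of the compounds shown alone.

Two compounds in this set have been run in a functional assay on CCRF-CEM cells (Homo sapiens) for cytotoxicity, read by sulforhodamine B assay, with a stated time of 48 h, tested at 1 uM; on this read-out higher numbers stand for a weaker effect at the one concentration tested and lower numbers for a stronger effect. Compound 1 `COc1cc(C)cc(-c2nn(CC#N)cc2-c2ccc(-c3cccc(C(C)=O)c3)nc2)c1` gives 13% in this assay, and compound 2 `Cc1cc(O)cc(-c2nn(CC#N)cc2-c2ccnc(-c3ccc(Oc4ccccc4)cc3)c2)c1` gives 6%. The two numbers lie within the scatter of each other, so neither can be set apart from the other on this read-out; compound 2 simply carries the lower of the two figures. The unmeasured compound 3 `Cc1cc(O)cc(-c2nn(CC#N)cc2-c2ccnc(-c3ccc(N(C)C)cc3)c2)c1` departs from compound 2 in one place: dimethylamino in place of phenoxy on an aromatic carbon. Within the data shown here, no measured pair shows this change, so its effect in this assay is unknown. Because compound 2 gives 6% and compound 1 gives 13%, a strong effect is the starting point for the shared core. The expected step is a number 9 percentage points higher from compound 2 to compound 3 (within the scatter), a modest move toward a weaker effect that would most likely stay within the scatter. Compound 3 is estimated to give 15% in this assay, between 4% and 45%.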

Compound 3, a percentage reported as activity, at one concentration (the size of the read-out at that concentration, not a potency): 13%
Compound 3: the middle estimate sits 2 percentage points above what was measured, within the range that was stated.
By their numbers in this assay, from the lowest: compounds 2, 1 and 3 (each within the scatter of the next).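

In this assay, the exchange of phenoxy for dimethylamino on this aromatic carbon gives a number 7 percentage points higher from compound 2 to compound 3 (within the scatter), so the two compounds cannot be told apart on this read-out. Among these compounds, this is the first direct view of this position, and it shows that, in this one pair, a group with no ring can stand where phenoxy stands without a change beyond the scatter. Nothing available on this pair offers an explanation for the result.

The compounds shown leave open whether a morpholine, a carboxylic acid or a methoxy group on the same carbon would also stay within the scatter of compound 2. They also leave open whether dimethylamino would behave the same way on the core of compound 1, or at a concentration other than the one tested here.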